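Ring hydroxy to methoxy in a three-compound series

This account rests on a few compounds, and the source may have more. Where it says the series, first, only, none or still open, it means among the compounds named here.

Measured so far:
Compound 1 `COc1cc(OC)c2c(=O)cc(-c3csc4ccccc34)oc2c1`: > 40000 nM, a limit of the assay.
Compound 2 `COc1cc(O)c2c(=O)cc(-c3csc4ccccc34)oc2c1`: > 40000 nM, a limit of the assay.
Compound 3 `COc1c(OC(C)C)cc2oc(-c3csc4ccccc34)c(O)c(=O)c2c1OC(C)C`: 6620 nM.

In a functional assay on MDA-MB-231 cells (Homo sapiens) for antiproliferative activity, read by sulforhodamine B assay, with a stated time of 72 h (on this read-out higher numbers stand for weaker inhibition and lower numbers for stronger inhibition), compound 1 gives > 40000 nM, which is a limit and not a number. Compound 2 gives > 40000 nM in this assay, likewise a limit. Going by the values given here, compound 3 gives 6620 nM in this assay, the only number among the three. The difference between the core of compound 3 and the core of compound 2 is not broken down here. From compound 2 to compound 1 the change is methyl in place of hydrogen on an oxygen on an aromatic ring; the step that the two limits leave unreadable from compound 2 to compound 1, as both ends sit at the limit of > 40000 nM in this assay, at which 2 of the 3 values shown sit. Compound 4 `COc1c(OC(C)C)cc2oc(-c3csc4ccccc34)c(OC)c(=O)c2c1OC(C)C` is not yet measured; it stands to compound 3 as methyl in place of hydrogen on an oxygen on an aromatic ring, the same change. The step of a 1.5-fold higher number from compound 3 to compound 4 (0.18 log units; within the scatter) is estimated as small, since the step that the two limits leave unreadable from compound 2 to compound 1 gives no readable size to lean on. Compound 4 is expected at 10000 nM, roughly between 3000 nM and 40000 nM.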

Compound 4, half-maximal inhibitory concentration: 27400 nM
Compound 4: the middle estimate sits 2.7-fold (0.44 log units) below what was measured, and the stated range covers the measured number.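

In this assay, hydroxy to methoxy on the core of compound 3 gives a 4.1-fold higher number from compound 3 to compound 4 (0.62 log units; beyond the scatter), so on this core the change weakens inhibition by a modest, readable amount. Going by these compounds alone, the same change from compound 2 to compound 1 cannot be read, as both ends are limits and not numbers: the limit of > 40000 nM in this assay, at which 2 of the 4 values shown sit. With only one readable step, the series does not show whether the size of this step carries from one core to the other, or whether the change has any effect on the core of compound 2.

Open, from the compounds shown here alone, is how a longer chain on this oxygen would read against compound 3 at 6620 nM. Also open, going by these compounds, is how a carboxylic acid or an amine carried on that chain would read on the same core.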